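Swapping Acetyl for Phenyl on an Amine Nitrogen

The source may hold more compounds than are shown below. What is called first, only, known or untested is meant among the compounds shown, and "the series" means these compounds.

Compound 1 `O=C1Nc2ccc(S(=O)(=O)N3CCOCC3)cc2/C1=N/c1cccc(C(F)(F)F)c1`: 15900 nM
Compound 2 `CC(=O)N/N=C1\C(=O)Nc2ccc(S(=O)(=O)N3CCOCC3)cc21`: 29000 nM

In a functional assay on HCT-116 cells (Homo sapiens) for cytotoxicity, read by sulforhodamine B assay, with a stated time of 24 h (a lower number here means a stronger inhibitor, a higher number a weaker inhibitor), compound 2 gives 29000 nM and compound 1 gives 15900 nM, and these two numbers lie within the scatter of each other. Among the measured compounds shown here, with only this pair measured, compound 2 cannot be ranked apart from compound 1.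

The next compound to be measured is compound 3 `O=C1Nc2ccc(S(=O)(=O)N3CCOCC3)cc2/C1=N/Nc1ccccc1`, which has phenyl in place of acetyl on an amine nitrogen. Put another way, acetamido becomes anilino.

For the measured compounds named here, only one measured step bears on this change, acetamido in place of 3-(trifluoromethyl)phenyl on a double-bonded nitrogen: a 1.8-fold higher number from compound 1 to compound 2 (0.26 log units; within the scatter). With that step this small, bringing a phenyl ring back in compound 3 is expected to shift the number only slightly in this assay, if at all toward the value of compound 1. One step is thin evidence, so the range is kept wide. The estimated step is a 1.5-fold lower number from compound 2 to compound 3 (0.18 log units; within the scatter), and nothing beyond the scatter is expected. The expected value for compound 3 is 19000 nM, with an estimated range of 8000 nM to 45000 nM.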

Compound 3, half-maximal inhibitory concentration: 10500 nM
The estimate for compound 3 lay 1.8-fold (0.26 log units) above the measured number; the range from low to high includes it.
By their numbers in this assay, from the lowest: compounds 3, 1 and 2 (each within the scatter of the next, the first and the last beyond it).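

Among the compounds shown here, putting phenyl in place of acetyl on an amine nitrogen gives a 2.8-fold lower number from compound 2 to compound 3 (0.44 log units; beyond the scatter) in this assay, the first step in this short series to lie beyond the scatter, so the group at this position can make a modest difference to the number. The other new step, a 1.5-fold lower number from compound 1 to compound 3 (0.18 log units; within the scatter), lies within the scatter, so anilino and 3-(trifluoromethyl)phenyl on the double-bonded nitrogen cannot be told apart in this assay, and only acetamido in compound 2 stands apart, and then only from compound 3. No measurement is available that explains the change from acetyl to phenyl, so the size of the step remains an observation without a known cause.

The compounds shown leave open whether the aromatic ring itself matters or whether any larger carbon group would serve as well, a question that a cyclohexyl ring or a benzyl group on the same amine nitrogen could address. Also open, on these data alone, is how far the number would move with a chlorine atom or a methoxy group on the phenyl ring of compound 3.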